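Swapping a Phenyl for a Carbamate on the Ring Nitrogen

A few compounds are considered here, and "the series" means these few. Any claim that something is new, unique, unknown or untested is made for them only; others in the source may bear on it.

Three compounds share a core and differ in the group on an amine nitrogen in a ring. Compound 1 `CC(C)(C)OC(=O)N1CCN(CC(=O)Nc2ccc(C(=O)/C=C/c3cn(Cc4ccc(Br)cc4)nn3)cc2)CC1` carries a tert-butoxycarbonyl group there and, in a functional assay on SK-N-SH cells (Homo sapiens) for inhibition, read by MTT assay (a higher number here means a weaker inhibitor, a lower number a stronger inhibitor), compound 1 gives 25800 nM. Compound 2 `CCCCCCCCn1cc(/C=C/C(=O)c2ccc(NC(=O)CN3CCN(c4ccccc4OC)CC3)cc2)nn1` has a methoxy-bearing phenyl at that nitrogen and gives 21500 nM; compound 3 `CCCCCCCCn1cc(/C=C/C(=O)c2ccc(NC(=O)CN3CCN(c4ccccc4)CC3)cc2)nn1` has a plain phenyl and gives 41400 nM. Compound 3 has the largest of the three numbers, but its distances to compound 1 and to compound 2 are both within the usual scatter, so the three cannot be told apart. Among the measured compounds shown here, the only measured step, a 1.9-fold higher number from compound 2 to compound 3 (0.28 log units; within the scatter), also stays within the scatter.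

Compound 4 `CCCCCCCCn1cc(/C=C/C(=O)c2ccc(NC(=O)CN3CCN(C(=O)OC(C)(C)C)CC3)cc2)nn1` differs from compound 3 by tert-butoxycarbonyl in place of phenyl on an amine nitrogen in a ring. For the measured compounds named here, no measured step makes exactly this change; the closest guide is compound 1, which already carries the tert-butoxycarbonyl group on a different core variant and gives 25800 nM. Given that compound 1 and compound 3 sit within scatter of each other, compound 4 is expected to show a 1.4-fold lower number from compound 3 to compound 4 (0.14 log units; within the scatter), meaning no shift beyond the scatter. Compound 4 is therefore estimated at 30000 nM, with a range from 12000 nM to 75000 nM.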

Compound 4, half-maximal inhibitory concentration: 38000 nM
Compound 4: the middle estimate sits 1.3-fold (0.10 log units) below what was measured, and the stated range covers the measured number.
By their numbers in this assay, from the lowest: compounds 2, 1, 4 and 3 (each within the scatter of the next).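

In this assay the ring nitrogen now has direct comparisons on the shared core: tert-butoxycarbonyl in place of phenyl gives a 1.1-fold lower number from compound 3 to compound 4 (0.04 log units; within the scatter) and in place of 2-methoxyphenyl gives a 1.8-fold higher number from compound 2 to compound 4 (0.25 log units; within the scatter), so at this nitrogen these groups, with or without an aromatic ring, cannot be told apart. With tert-butoxycarbonyl held on the ring nitrogen, heptyl in place of 4-bromophenyl on a saturated chain carbon bound to an aromatic nitrogen gives a 1.5-fold higher number from compound 1 to compound 4 (0.17 log units; within the scatter), so this second place also shows no shift beyond the scatter. No evidence is available that bears on this result.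

Going by these compounds, whether any group on this ring nitrogen can move the number beyond the scatter remains open. A plain amine hydrogen or a carboxylic acid-bearing chain there could begin to answer that.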